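Aromatic substituent exchange: expectation for compound 3

The source may report more compounds than this note shows. Statements on the series, on what has been measured and on what is new or still open speak of the compounds shown alone.

Two measured compounds share one core and differ only in the group on one aromatic carbon: compound 1 `O=C(Nc1nc(-c2cccc(Cl)c2)cs1)c1ccc([N+](=O)[O-])o1` and compound 2 `O=C(Nc1nc(-c2cccc(OC3CCCC3)c2)cs1)c1ccc([N+](=O)[O-])o1`. In an ADME assay on Vero cells (Chlorocebus sabaeus) for cytotoxicity, read by MTT assay, with a stated time of 72 h (a higher number here means a weaker inhibitor, a lower number a stronger inhibitor), compound 1 gives 43700 nM, and compound 2 gives 81100 nM, the higher of the two numbers, though the gap stays inside the scatter. Compound 3 `O=C(Nc1nc(-c2cccc(NC(=O)C3CC3)c2)cs1)c1ccc([N+](=O)[O-])o1` differs from compound 2 by (cyclopropylcarbonyl)amino in place of cyclopentyloxy on an aromatic carbon. Among the compounds with values here, the only measured step at this place is a 1.9-fold higher number from compound 1 to compound 2 (0.27 log units; within the scatter). The expected step is accordingly a 1.4-fold lower number from compound 2 to compound 3 (0.13 log units; within the scatter), nothing beyond the scatter. Compound 3 is estimated at 60000 nM, range 25000 nM to 150000 nM.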

Compound 3, half-maximal inhibitory concentration: 35700 nM
Compound 3: middle estimate off by 1.7-fold (0.23 log units), on the high side; the measured number falls inside the stated range.
By their numbers in this assay, from the lowest: compounds 3, 1 and 2 (each within the scatter of the next, the first and the last beyond it).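

In this assay this position now shows a step beyond the scatter, though a modest one (a 2.3-fold lower number from compound 2 to compound 3 (0.36 log units; beyond the scatter)), with (cyclopropylcarbonyl)amino in place of cyclopentyloxy, two groups of 6 heavy atoms. The chloro group and (cyclopropylcarbonyl)amino cannot be separated here (a 1.2-fold lower number from compound 1 to compound 3 (0.09 log units; within the scatter)), so the amide group gives no reading distinct from chloro. Nothing available explains the step. From the compounds shown here alone, whether an amine or a carboxylic acid on this aromatic carbon would move the number further remains open. Also open, going by these compounds, is whether the step from cyclopentyloxy holds with a longer chain on the amide carbonyl.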